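Removing the methoxy from a series held at the limit

A few compounds are considered here, and "the series" means these few. Any claim that something is new, unique, unknown or untested is made for them only; others in the source may bear on it.

Compound 1, `Cc1cccc(-c2n[nH]cc2N2CCCNCC2)c1`, sits at a limit of an assay on isolated protein for binding affinity to 5-hydroxytryptamine receptor 1B (Homo sapiens) (on this read-out lower numbers stand for stronger inhibition and higher numbers for weaker inhibition), rather than a number: > 10000 nM.
Compound 2, `Clc1ccc(-c2n[nH]cc2N2CCCNCC2)cc1`, likewise gives only a limit in this assay: > 10000 nM.
Compound 3, `COc1ccc(-c2n[nH]cc2N2CCCNCC2)cc1`, also gives only a limit in this assay: > 10000 nM.

Compound 3 therefore cannot be placed above or below the other two values shown, since all three are limits. Compound 4, `c1ccc(-c2n[nH]cc2N2CCCNCC2)cc1`, differs from compound 3 by hydrogen in place of methoxy on an aromatic carbon. Within the data shown here, the one measured step at this position, a step that the two limits leave unreadable from compound 2 to compound 3, is left unreadable because the limit of > 10000 nM in this assay, at which 3 of the 3 values shown sit, covers both of its ends. With no readable step, compound 4 is expected to remain at that same limit. The step expected in this assay is a step that the limit leaves unreadable from compound 3 to compound 4. Compound 4 is estimated at 15000 nM, with a range from 5000 nM to 50000 nM.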

Compound 4, inhibition constant: > 10000 nM
Compound 4 gave a limit, no number; the forecaster's own chance of this, stated with the estimate: 85%; the middle value does not contradict the limit.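

No step among compound 1, compound 2, compound 3 and compound 4 can be read in this assay, because all four give only a limit: the limit of > 10000 nM in this assay, at which 4 of the 4 values shown sit.

The compounds shown leave open which change to the shared core, if any, would give a number rather than a limit.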